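Trifluoromethylphenyl triazole ester of a hydroxylated triterpenoid

A few compounds are considered here, and "the series" means these few. Any claim that something is new, unique, unknown or untested is made for them only; others in the source may bear on it.

Compound 1 `C/C(=C\CC/C(C)=C/CC[C@@H]1[C@@]2(C)CCC(=O)C(C)(C)[C@H]2CC[C@@]1(C)O)CC/C=C(\C)C(=O)OCc1cn(-c2ccccc2C)nn1` was examined in a functional assay on DU-145 cells (Homo sapiens) for antiproliferative activity, read by MTT assay, with a stated time of 48 h; a higher number here means a weaker inhibitor, a lower number a stronger inhibitor. Compound 1 gives > 150000 nM there, which is a limit of the assay and not a number. Compound 2 `C/C(=C\CC/C(C)=C/CC[C@@H]1[C@@]2(C)CCC(=O)C(C)(C)[C@H]2CC[C@@]1(C)O)CC/C=C(\C)C(=O)OCc1cn(-c2ccc(C)cc2)nn1` differs from it only on the aromatic nitrogen. Compound 2 also gives a limit, > 150000 nM. The step that the two limits leave unreadable from compound 1 to compound 2 is therefore unreadable, since both values sit at the limit of > 150000 nM in this assay, at which 2 of the 2 values shown sit. Compound 3 `C/C(=C\CC/C(C)=C/CC[C@@H]1[C@@]2(C)CCC(=O)C(C)(C)[C@H]2CC[C@@]1(C)O)CC/C=C(\C)C(=O)OCc1cn(-c2cccc(C(F)(F)F)c2)nn1` carries 3-(trifluoromethyl)phenyl in place of 2-methylphenyl on an aromatic nitrogen. Among the compounds with values here, the only measured step touching this position is the unreadable one, so no size or direction can be drawn from it, and the two measured values give no sign that a change on this aromatic nitrogen moves the read-out away from the limit. Compound 3 is therefore expected to give about 150000 nM, within 40000 nM to 400000 nM, most likely reported as a limit once more. The step of a number no higher from compound 1 to compound 3 (the limit leaves the size open) is estimated to be small.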

Compound 3, half-maximal inhibitory concentration: > 150000 nM
Compound 3: no number, only a limit (the forecaster's own chance of this, stated with the estimate: 80%); the middle value lies on the limit itself.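

Compound 3 also stops at a limit in this assay, so no step among compound 1, compound 2 and compound 3 can be read: the limit of > 150000 nM in this assay, at which 3 of the 3 values shown sit.

These compounds leave open whether any group on this aromatic nitrogen would give a real number rather than a limit.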